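The compounds below may be only part of what the source reports. "The series", "measured", "known", "first", "only" and "open" are said of these compounds alone.

Compound 1 `COc1cc(C(=O)Nc2nn[nH]n2)nc(-c2ccccc2)c1` gives 97% in a functional assay on the whole organism with Rattus norvegicus as the target, at a dose of 3 mg/kg by the oral route; a lower number here means a weaker effect, a higher number a stronger effect of the compound at the dose given.
Compound 2 `CCCCc1ccc(-c2cc(OC)cc(C(=O)Nc3nn[nH]n3)n2)cc1` gives 61% in this assay.
Compound 3 `CCc1cc(C(=O)Nc2nn[nH]n2)nc(-c2ccccc2)c1` gives 53% in this assay.

The change from compound 1 to compound 2, (butyl in place of hydrogen on an aromatic carbon), went along with a number 36 percentage points lower from compound 1 to compound 2 (beyond the scatter). Compound 3 differs from compound 1 in its core, (ethyl in place of methoxy on an aromatic carbon), and that change went along with a number 44 percentage points lower from compound 1 to compound 3 (beyond the scatter). Compound 2 and compound 3 give numbers within the usual scatter of each other, so nothing separates them. Compound 4 `CCCCc1ccc(-c2cc(CC)cc(C(=O)Nc3nn[nH]n3)n2)cc1` has not yet been measured; it carries the same change that compound 2 carries, (butyl in place of hydrogen on an aromatic carbon), now placed on the core of compound 3. For the measured compounds named here, for compound 4 the expected step is a number 31 percentage points lower from compound 3 to compound 4 (beyond the scatter), resting on the one earlier instance of this change, in which compound 2 gave 61% against compound 1, and on the lower starting point of compound 3 at 53%, which leaves less room for the number to fall. The estimate for compound 4 is 22%, between 5% and 48%.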

Compound 4, a percentage reported as inhibition, in the whole organism at one dose (the size of the read-out at that dose, not a potency): 70%
Compound 4: the middle estimate sits 48 percentage points below what was measured; measured number above the stated range.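

In this assay the butyl group did not carry over from one core to the other: on the core of compound 3 its addition gave a number 17 percentage points higher from compound 3 to compound 4 (beyond the scatter) and so ran opposite to the earlier step: the same change on two cores in this assay, a number 36 percentage points lower (beyond the scatter) from compound 1 to compound 2 and a number 17 percentage points higher (beyond the scatter) from compound 3 to compound 4, 53 percentage points apart, beyond the scatter of two such steps. The ethyl for methoxy change also did not carry over, giving a number 9 percentage points higher from compound 2 to compound 4 (within the scatter) once the butyl group was present, which leaves that pair unseparated, unlike the pair without butyl: the same change on two cores in this assay, a number 44 percentage points lower (beyond the scatter) from compound 1 to compound 3 and a number 9 percentage points higher (within the scatter) from compound 2 to compound 4, 53 percentage points apart, beyond the scatter of two such steps. Across these four compounds, then, the effect of each change depends on what stands at the other place, but this single pair of cores at one dose neither explains that dependence nor gives a rule for any other core.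

The compounds shown leave open whether a shorter chain such as propyl, or an amine or a carboxylic acid, on the same aromatic carbon would follow the butyl group on each core. They also leave open how ethoxy or chloro in place of methoxy would behave with and without the butyl group.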